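The source may report more compounds than this note shows. Statements on the series, on what has been measured and on what is new or still open speak of the compounds shown alone.

Three compounds built on one shared core have been examined in a functional assay on MDA-MB-231 cells (Homo sapiens) for inhibition, read by sulforhodamine B assay, with a stated time of 48 h; a higher number here means that more compound is tolerated, a lower number that less compound is tolerated. Compound 1 `O=C(Nc1cccc(-n2cc(-c3ccncc3)c(-c3ccc(Cl)c(O)c3)n2)c1)Nc1cccc(C(F)(F)F)c1` gives > 32500 nM, which is a limit of the assay and not a number. Compound 2 `O=C(Nc1cccc(-n2cc(-c3ccncc3)c(-c3ccc(Cl)c(O)c3)n2)c1)Nc1ccc(Cl)c(Cl)c1` gives > 32500 nM, again a limit. The step that the two limits leave unreadable from compound 1 to compound 2 is therefore unreadable. Within the data shown here, compound 3 `COc1cc(-c2nn(-c3cccc(NC(=O)Nc4ccc(Cl)c(C(F)(F)F)c4)c3)cc2-c2ccncc2)ccc1Cl` gives 13300 nM, the only measured number among the three; the other two values stop at the limit of > 32500 nM in this assay, at which 2 of the 3 values shown sit.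

Compound 4 `O=C(Nc1cccc(-n2cc(-c3ccncc3)c(-c3ccc(Cl)c(O)c3)n2)c1)Nc1ccc(Cl)c(C(F)(F)F)c1` keeps the amide-side aryl of compound 3 and differs from it only in hydrogen in place of methyl on an oxygen on an aromatic ring, that is methoxy to hydroxy, 4-chloro-3-methoxyphenyl to 4-chloro-3-hydroxyphenyl. Among the measured compounds shown here, none of the measured steps follows this exchange on its own, and the single measured step is unreadable. Compounds 1 and 2 carry the hydroxy and each reports only a limit. Compound 3 carries the methoxy and reports a number. Those pairs differ in two places, so their values can be set side by side but not read as a step. On that basis compound 4 is expected to be tolerated at higher concentration than compound 3, by about a 2.3-fold higher number from compound 3 to compound 4 (0.35 log units; beyond the scatter) in this assay, with a fair chance that only a limit is reported. Compound 4 is accordingly estimated at 30000 nM, with a range from 12000 nM to 80000 nM.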

Compound 4, concentration lethal to 50% of the cells: 11400 nM
The estimate for compound 4 lay 2.6-fold (0.42 log units) above the measured number; measured number outside the range, below it.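

In this assay, hydrogen in place of methyl on an oxygen on an aromatic ring gives a 1.2-fold lower number from compound 3 to compound 4 (0.07 log units; within the scatter) and so gives this position its first readable step, one that stays within the scatter. Compound 4 also shows that a hydroxy compound can give a measured number, which compound 1 and compound 2 did not: trifluoromethyl in place of chloro on an aromatic carbon gives an at least 2.8-fold lower number from compound 2 to compound 4 (0.45 log units; beyond the scatter) and chloro in place of hydrogen on an aromatic carbon gives an at least 2.8-fold lower number from compound 1 to compound 4 (0.45 log units; beyond the scatter) with the hydroxy kept. Among the hydroxy compounds shown, only the one whose amide-side aryl carries both chloro and trifluoromethyl gives a measured number, while the other two values remain limits of the assay: the limit of > 32500 nM in this assay, at which 2 of the 4 values shown sit.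

From the compounds shown here alone, the step from compound 1 to compound 2 cannot be read, and whether methoxy and hydroxy also stay within the scatter of each other with a different amide-side aryl remains open. Also open, going by these compounds, is how an amine, a carboxylic acid or a longer chain such as ethoxy at this oxygen-bearing position would read in this assay on the shared core.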